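Changing the Carbonyl Substituent on the Piperazine of Compound 2

The source may hold more compounds than are shown below. What is called first, only, known or untested is meant among the compounds shown, and "the series" means these compounds.

Measured compounds, with their values in an assay on isolated protein for binding affinity to histamine H2 receptor (Homo sapiens); a higher number here means a weaker inhibitor, a lower number a stronger inhibitor:
- compound 1, `CCCCCC(=O)c1ccc(OCCCN2CCN(C(=O)OCC(C)C)CC2)cc1`: 3720 nM
- compound 2, `CCCCCC(=O)c1ccc(OCCCN2CCN(C(=O)N3CCOCC3)CC2)cc1`: 17800 nM
- compound 3, `CCCCCC(=O)c1ccc(OCCCN2CCN(C(=O)CSCC)CC2)cc1`: 22900 nM

Among these three numbers, compound 2 stands second highest. Its nearest neighbour is compound 3, and that gap, a 1.3-fold higher number from compound 2 to compound 3 (0.11 log units; within the scatter), lies within the scatter. Its furthest neighbour is compound 1, separated by a 4.8-fold higher number from compound 1 to compound 2 (0.68 log units; beyond the scatter), which is a modest step beyond the scatter.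

Compound 4, `CCCCCC(=O)c1ccc(OCCCN2CCN(C(=O)C(C)(C)O)CC2)cc1`, differs from compound 2 in one place: 1-hydroxy-1-methylethyl in place of morpholin-4-yl on a carbonyl carbon. Two of the measured steps bear on such a change of the group on the carbonyl carbon. The step of a 4.8-fold higher number from compound 1 to compound 2 (0.68 log units; beyond the scatter) was modest, and the step of a 1.3-fold higher number from compound 2 to compound 3 (0.11 log units; within the scatter) stayed within the scatter, so replacing the morpholin-4-yl group by a different small group has so far moved the number little or not at all. For compound 4 the expectation in this assay is therefore a step of about a 1.2-fold lower number from compound 2 to compound 4 (0.07 log units; within the scatter), not beyond the scatter in either direction. The estimate for compound 4 is 15000 nM, within a range from 5000 nM to 45000 nM.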

Compound 4, inhibition constant: 24500 nM
Beside the measured number, compound 4's estimate is 1.6-fold (0.21 log units) below it, and the stated range covers the measured number.
By their numbers in this assay, from the lowest: compound 1; then compounds 2, 3 and 4 (each within the scatter of the next).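

Swapping morpholin-4-yl, with its ring and no hydrogen-bond donor, for 1-hydroxy-1-methylethyl, with a hydrogen-bond donor and no ring, gives a 1.4-fold higher number from compound 2 to compound 4 (0.14 log units; within the scatter) in this assay and so stays within the scatter. Among these compounds, with a 1.1-fold higher number from compound 3 to compound 4 (0.03 log units; within the scatter) as well, the three groups on this carbonyl carbon in compounds 2, 3 and 4 cannot be told apart, while a 6.6-fold higher number from compound 1 to compound 4 (0.82 log units; beyond the scatter) leaves isobutoxy in compound 1 as the only group here that stands apart from the other three. No supporting evidence bears on this result.

On these data alone, it remains open whether the separation of compound 1 depends on the oxygen of isobutoxy or on its branched carbon chain. An ethoxy or a plain isobutyl group on the same carbonyl carbon would separate these two possibilities, and a dimethylamino group would extend the comparison with morpholin-4-yl.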